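The source may hold more compounds than are shown below. What is called first, only, known or untested is meant among the compounds shown, and "the series" means these compounds.

Compound 2 `Cc1noc(NS(=O)(=O)c2cccc3c(N4CCCCC4=O)cccc23)c1C` is the reference point here. In an assay on VSM-A10 cells for antagonist activity at Endothelin-1 receptor (Rattus norvegicus) (on this read-out lower numbers stand for stronger inhibition and higher numbers for weaker inhibition), compound 2 gives 270 nM, the lowest of the three numbers in hand. Compound 1 `Cc1noc(NS(=O)(=O)c2ccc(NC(=O)CN)cc2)c1C` sits nearest to it, and in this assay compound 1 gives 6500 nM, a gap that lies beyond the usual scatter. Compound 3 `Cc1noc(NS(=O)(=O)c2cccc3c(N(C)C)cccc23)c1Cc1ccccc1` lies furthest away, and in this assay compound 3 gives 50000 nM, also well beyond the scatter. Compound 3 differs from compound 2 in more than one place, so its number alone cannot be tied to any single change.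

The unmeasured compound 4 `Cc1noc(NS(=O)(=O)c2cccc3c(NC(C)C)cccc23)c1C` differs from compound 2 in one place only: isopropylamino in place of 2-oxopiperidin-1-yl on an aromatic carbon. Among the compounds with values here, no pair of measured compounds shows this exact change, so no measured step can be borrowed. What is known is that the two compounds carrying a smaller nitrogen group at the same place on the core, compound 1 and compound 3, both give higher numbers than compound 2. On that basis the step from compound 2 to compound 4 is expected to be a loss, estimated at a 5.6-fold higher number from compound 2 to compound 4 (0.74 log units; beyond the scatter), beyond the scatter but uncertain in size. Compound 4 is therefore estimated to give 1500 nM, within a range of 300 nM to 8000 nM.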

Compound 4, half-maximal inhibitory concentration: 20 nM
Beside the measured number, compound 4's estimate is 75-fold (1.88 log units) above it; measured number below the stated range.
By their numbers in this assay, from the lowest: compound 4; then compound 2; then compound 1; then compound 3.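

Within the data shown here, this is the first step at this place on the shared core that comes with no other change: in this assay, isopropylamino in place of 2-oxopiperidin-1-yl gives a 14-fold lower number from compound 2 to compound 4 (1.13 log units; beyond the scatter). It shows that this aromatic carbon can carry a group with no ring and fewer heavy atoms without any loss, and that the choice of group here can shift the number by a large amount. The change alters several things at once, removing the ring and the double bond outside aromatic rings and adding a hydrogen-bond donor, and nothing available here explains the step or ties it to any one of these differences.

The compounds shown leave open which of these differences matters, and whether isopropylamino is the best of the simple nitrogen groups at this place. Comparing compound 4 with close relatives carrying methylamino, cyclopentylamino or an isopropylamino group with an added methyl on its nitrogen would help to separate the size of the group, the presence of a ring and the role of the hydrogen on the nitrogen.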